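Amino in place of bromo: an expected rise

The source may hold more compounds than are shown below. What is called first, only, known or untested is meant among the compounds shown, and "the series" means these compounds.

Among the compounds with values here, in a functional assay (aorta) with Oryctolagus cuniculus as the target (a higher number here means weaker binding, a lower number tighter binding), compound 3 `Fc1ccc(C(c2ccc(F)cc2)C2CCN(CCCOc3ccc(Br)cc3)CC2)cc1` gives 1.59 nM, the lowest of the three numbers measured so far. Compound 1 `COc1cc(C(C)O)ccc1OCCCN1CCC(C(c2ccc(F)cc2)c2ccc(F)cc2)CC1` gives 10 nM, and compound 2 `COc1cc(C(=O)O)ccc1OCCCN1CCC(C(c2ccc(F)cc2)c2ccc(F)cc2)CC1` gives 79.4 nM. Compound 4 `Nc1ccc(OCCCN2CCC(C(c3ccc(F)cc3)c3ccc(F)cc3)CC2)cc1` differs from compound 3 at one place, with amino in place of bromo on an aromatic carbon. Within the data shown here, no measured pair isolates this exchange. The closest evidence is indirect, as both relevant steps replace a whole substituted ring with 4-bromophenyl. These are the modest 6.3-fold lower number from compound 1 to compound 3 (0.80 log units; beyond the scatter) and the large 50-fold lower number from compound 2 to compound 3 (1.70 log units; beyond the scatter). Neither ring carries amino, so these steps give only a direction and a rough ceiling for the size. Because the two rings that lack bromo gave higher numbers in a 6.3-fold lower number from compound 1 to compound 3 (0.80 log units; beyond the scatter) and a 50-fold lower number from compound 2 to compound 3 (1.70 log units; beyond the scatter), a modest move towards a higher number is expected in this assay. The expected change is a 3.8-fold higher number from compound 3 to compound 4 (0.58 log units; beyond the scatter). Compound 4 is estimated at 6 nM, with an expected range of 1.5 nM to 25 nM.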

Compound 4, dissociation constant: 31.6 nM
Compound 4: the middle estimate sits 5.3-fold (0.72 log units) below what was measured, outside the stated range (above it).
By their numbers in this assay, from the lowest: compound 3; then compound 1; then compound 4; then compound 2.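

In this assay, this one-atom exchange on an aromatic carbon, para to a large group, is a large step by itself (a 20-fold higher number from compound 3 to compound 4 (1.30 log units; beyond the scatter)). The earlier compounds shown here changed whole rings, so they could not separate the bromo from the absence of the other ring substituents. Compound 4 also lacks those substituents, yet its steps from the two substituted rings are only modest (a 2.5-fold lower number from compound 2 to compound 4 (0.40 log units; beyond the scatter); a 3.2-fold higher number from compound 1 to compound 4 (0.50 log units; beyond the scatter)), so the low number of compound 3 goes with the bromo at this place and not with the plainer ring alone. Nothing available explains why the number rises with this exchange.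

Open, as far as these compounds go, is whether chloro, methyl or a nitrile at this place would stay close to compound 3 or move towards compound 4. Also open, from the compounds shown here alone, is where an acetamide would fall.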